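The compounds below may be only part of what the source reports. "The series", "measured", "known", "first", "only" and "open" are said of these compounds alone.

Working notes on the series. Compound 1 `Cn1cc([N+](=O)[O-])cc1-c1nnc(-c2ccco2)o1` gives 191000 nM in an ADME assay on Vero cells (Chlorocebus sabaeus) for cytotoxicity, read by MTT assay, with a stated time of 72 h; a higher number here means a weaker inhibitor, a lower number a stronger inhibitor. Compound 2 `Cn1cc([N+](=O)[O-])cc1-c1nnc(C2CCCNC2)o1` gives 611000 nM in this assay, and compound 3 `Cn1cc([N+](=O)[O-])cc1-c1nnc(-c2ccns2)o1` gives 320000 nM in this assay. Compound 2 holds the highest of the three numbers: the step of a 1.9-fold lower number from compound 2 to compound 3 (0.28 log units; within the scatter) stays within the scatter, while a 3.2-fold higher number from compound 1 to compound 2 (0.51 log units; beyond the scatter) lies beyond it; the step of a 1.7-fold higher number from compound 1 to compound 3 (0.22 log units; within the scatter) is within the scatter.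

Compound 4 `O=[N+]([O-])c1c[nH]c(-c2nnc(C3CCCNC3)o2)c1` differs from compound 2 by hydrogen in place of methyl on an aromatic nitrogen. For the measured compounds named here, every measured step in this assay exchanges the group on an aromatic carbon; none touches the aromatic nitrogen, so no measured step bears directly on this change, and the three values give no basis for a direction. The step from compound 2 to compound 4 in this assay is expected to be none beyond the scatter, a 1.0-fold lower number from compound 2 to compound 4 (0.01 log units; within the scatter). Compound 4 is estimated at 600000 nM in this assay, with a range from 250000 nM to 1500000 nM.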

Compound 4, half-maximal inhibitory concentration: 318000 nM
Compound 4: middle estimate off by 1.9-fold (0.28 log units), on the high side; low and high end bracket the measured number.
By their numbers in this assay, from the lowest: compounds 1, 4, 3 and 2 (each within the scatter of the next, the first and the last beyond it).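

Hydrogen in place of methyl on the aromatic nitrogen gives a 1.9-fold lower number from compound 2 to compound 4 (0.28 log units; within the scatter) in this assay, so at this position the methyl can go without a difference that stands out from the scatter. For the compounds shown here, this is the first reading at this position, as all earlier steps exchange the group on an aromatic carbon, and it adds the aromatic nitrogen to the places read. No available data bear on what lies behind this result.

As far as these compounds go, whether the same holds with furan-2-yl or 1,2-thiazol-5-yl on the core stays open, as this step is read only with piperidin-3-yl in place. Also open, from the compounds shown here alone, is what an ethyl group, a longer chain or a chain ending in an amine on the aromatic nitrogen would give in this read-out.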